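Ring-nitrogen substituent series: aryl exchange at compound 4

This account rests on a few compounds, and the source may have more. Where it says the series, first, only, none or still open, it means among the compounds named here.

The series shares one core and is varied only at an amide-type nitrogen in a ring. Compound 1 `CC(C)[C@@H]1CC[C@@H](C)C[C@@]12N(C)C(=O)[C@@H]1[C@H]3C(=O)NC(=O)[C@H]3ON12` carries hydrogen there; in a functional assay, read by spectrophotometry, with a stated time of 2 h, tested at 0.5 mg/mL (on this read-out higher numbers stand for a stronger effect at the one concentration tested and lower numbers for a weaker effect), compound 1 gives 25.9%. Compound 2 `CC(C)[C@@H]1CC[C@@H](C)C[C@@]12N(C)C(=O)[C@@H]1[C@H]3C(=O)N(C)C(=O)[C@H]3ON12` carries methyl, and in this assay compound 2 gives 36.5%. Compound 3 `CC(C)[C@@H]1CC[C@@H](C)C[C@@]12N(C)C(=O)[C@@H]1[C@H]3C(=O)N(c4ccc(Cl)cc4)C(=O)[C@H]3ON12` carries 4-chlorophenyl, and in this assay compound 3 gives 47.5%, the highest of the three numbers. The steps of a number 10.6 percentage points higher from compound 1 to compound 2 (beyond the scatter), a number 21.6 percentage points higher from compound 1 to compound 3 (beyond the scatter) and a number 11 percentage points higher from compound 2 to compound 3 (beyond the scatter) all lie beyond the scatter and all run upward.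

Compound 4 `Cc1ccc(N2C(=O)[C@H]3[C@H](ON4[C@@H]3C(=O)N(C)[C@@]43C[C@H](C)CC[C@H]3C(C)C)C2=O)c(C)c1` differs from compound 3 in one place: 2,4-dimethylphenyl in place of 4-chlorophenyl on an amide-type nitrogen in a ring. For the measured compounds named here, none of the measured steps exchanges one aryl group for another; each replaces hydrogen or methyl by a larger group, and each raised the number modestly. Since an aryl group is kept in compound 4, the nearest guide is the number for compound 3 itself, with a number 11 percentage points higher from compound 2 to compound 3 (beyond the scatter) marking the size of change that substitution on this nitrogen has produced so far. A step around the scatter, in either direction, is therefore expected, the expected step being a number 2.5 percentage points lower from compound 3 to compound 4 (within the scatter). Compound 4 is estimated at 45%, with a range from 30% to 60%.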

Compound 4, a percentage reported as activity, at one concentration (the size of the read-out at that concentration, not a potency): 51%
Beside the measured number, compound 4's estimate is 6 percentage points below it; the range from low to high includes it.
By their numbers in this assay, from the lowest: compound 1; then compound 2; then compounds 3 and 4 (each within the scatter of the next).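

In this assay, for the compounds shown here, the exchange of 4-chlorophenyl for 2,4-dimethylphenyl on the amide-type nitrogen is the first aryl-for-aryl step at this position, and it gives a number 3.5 percentage points higher from compound 3 to compound 4 (within the scatter), so this read-out does not separate the two aryl groups even though the chlorine is lost and the entering group is all carbon. The other two steps show that a second aryl group also stands clear of the smaller substituents, with a number 14.5 percentage points higher from compound 2 to compound 4 (beyond the scatter) and a number 25.1 percentage points higher from compound 1 to compound 4 (beyond the scatter), which extends to 2,4-dimethylphenyl what 4-chlorophenyl alone had shown. No measurement at hand explains why the aryl compounds sit at this level or why the change of ring substituents makes no visible difference.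

Still open, going by these compounds, is whether the level belongs to aryl groups in general or only to these two, since a phenyl ring carrying a carboxylic acid or an amine, a benzyl group or a longer alkyl chain such as n-butyl could fall anywhere on this scale. With a single tested concentration, the read-out also leaves open whether compound 3 and compound 4 would differ in potency.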